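A few compounds are considered here, and "the series" means these few. Any claim that something is new, unique, unknown or untested is made for them only; others in the source may bear on it.

Compound 1 `CCOc1ccccc1-n1nncc1CN1C(=O)C2(C(C#N)=C(N)Oc3c2c2nc4ccccc4nc2c2ccccc32)c2ccccc21` and compound 2 `N#CC1=C(N)Oc2c(N)cc3nc4ccccc4nc3c2C12C(=O)N(Cc1cnnn1-c1cccc(C(F)(F)F)c1)c1ccccc12` share a core and carry different aryl groups on the aromatic nitrogen of the triazole. In a functional assay on HCT-116 cells (Homo sapiens) for antiproliferative activity, read by MTT assay, with a stated time of 48 h (on this read-out higher numbers stand for weaker inhibition and lower numbers for stronger inhibition), compound 1 returns only a limit, > 50000 nM, and no number. Compound 2 in this assay gives 18900 nM, which is the only actual number shown, the other result being (the limit of > 50000 nM in this assay, at which 1 of the 2 values shown sits). Compound 3 `N#CC1=C(N)Oc2c(N)cc3nc4ccccc4nc3c2C12C(=O)N(Cc1cnnn1-c1c(Cl)cc(Cl)cc1Cl)c1ccccc12` has not yet been measured; it carries 2,4,6-trichlorophenyl in place of 3-(trifluoromethyl)phenyl on an aromatic nitrogen. Among the compounds with values here, no step between two measured compounds is available, so the size of this change cannot be read from any measured pair. Since one substituted phenyl ring replaces another at the same position, the change is expected to shift the value little, a 1.1-fold lower number from compound 2 to compound 3 (0.05 log units; within the scatter), staying within the usual scatter. Compound 3 is therefore estimated at 17000 nM in this assay, with a range from 6000 nM to 50000 nM.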

Compound 3, half-maximal inhibitory concentration: 12100 nM
Estimate against measurement, compound 3: 1.4-fold (0.15 log units) above; the range from low to high includes it.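

In this assay, within the data shown here, replacing 3-(trifluoromethyl)phenyl with 2,4,6-trichlorophenyl on the aromatic nitrogen gives the first step that can be read at this position: a 1.6-fold lower number from compound 2 to compound 3 (0.19 log units; within the scatter). Two phenyl rings with different substituents, one with trifluoromethyl and one with three chlorines, therefore give values that cannot be told apart on this shared core. Compound 1 remains a limit and not a number, so no step involving it can be read: the limit of > 50000 nM in this assay, at which 1 of the 3 values shown sits.

The compounds shown leave open whether a phenyl ring carrying an amine or a carboxylic acid, or an alkyl chain in place of the ring, would move the value beyond the scatter. They also leave open what the ethoxy-bearing phenyl ring of compound 1 would give on the core of compound 2.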